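Removing one methyl from the amide of compound 2

A few compounds are considered here, and "the series" means these few. Any claim that something is new, unique, unknown or untested is made for them only; others in the source may bear on it.

Two amides on the shared core have so far been run in a functional assay on the whole organism for inhibition, with Rattus norvegicus as the target, at a dose of 3 mg/kg by the oral route; a higher number here means a stronger effect of the compound at the dose given, a lower number a weaker effect. Compound 2 `Cc1cc(C)nc(C(=O)Nc2nn[nH]n2)c1` gives 44% in this assay. Compound 1 `O=C(Nc1nn[nH]n1)c1cc(Br)ccn1` gives 34% in this assay, a number within the usual scatter of that of compound 2; the two compounds differ in more than one place, so nothing is taken from the pair beyond the two values themselves. Compound 3 `Cc1cccc(C(=O)Nc2nn[nH]n2)n1` is not yet measured. Among the measured compounds shown here, it differs from compound 2 in one place: hydrogen in place of methyl on an aromatic carbon No step between two measured compounds is available to calibrate a change of this kind, so the expectation rests on the smallness of the change alone: in this assay a step of little or no size beyond the scatter, if anything toward a weaker read-out. Compound 3 is expected to give 36%, with a range from 22% to 50%. The step this estimate implies is a number 8 percentage points lower from compound 2 to compound 3 (within the scatter).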

Compound 3, a percentage reported as inhibition, in the whole organism at one dose (the size of the read-out at that dose, not a potency): 46%
Compound 3: middle estimate off by 10 percentage points, on the low side, within the range that was stated.
By their numbers in this assay, from the lowest: compounds 1, 2 and 3 (each within the scatter of the next, the first and the last beyond it).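

In this assay, among the compounds shown here, hydrogen in place of methyl on the aromatic carbon opposite the ring nitrogen comes to a number 2 percentage points higher from compound 2 to compound 3 (within the scatter), the first step that changes one place only. At this dose, the read-out therefore shows no measurable dependence on the methyl at this position, a point that the pair of compounds 1 and 2, which differ in more than one place, could not settle. No measurement of any property of these compounds bears on this result, so it remains an observation without an explanation.

Open, on these data alone, is whether this position accepts a group other than methyl, such as an ethyl chain, a methoxy group, an amine or a carboxylic acid. For the compounds shown here, the methyl that remains in compound 3 has no step of its own, and a read-out at one dose leaves any difference in potency unresolved.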